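A few compounds are considered here, and "the series" means these few. Any claim that something is new, unique, unknown or untested is made for them only; others in the source may bear on it.

Compound 1 `Nc1nc(Cl)c(-c2ncco2)c(N[C@@H]2C[C@H](CO)[C@@H](O)[C@H]2O)n1` gives in an ADME assay on cells (Homo sapiens) for cytotoxicity, read by polymerase chain reaction, with a stated time of 3 days (on this read-out lower numbers stand for higher toxicity in this test and higher numbers for lower toxicity in this test), only a limit, > 25000 nM. Among the measured compounds shown here, compound 2 `Nc1nc(Cl)c(-c2nc3ccccc3s2)c(N[C@@H]2C[C@H](CO)[C@@H](O)[C@H]2O)n1` gives in this assay 14000 nM, the only number among the values shown. Compound 2 therefore stands alone as a measured number. For the measured compounds named here, the single measured step is an at least 1.7-fold lower number from compound 1 to compound 2 (0.25 log units; that floor lies within the scatter), which the limit of > 25000 nM in this assay, at which 1 of the 2 values shown sits, leaves as a floor only. Compound 3 `Nc1nc(Cl)c(-c2nc3ccc(F)cc3s2)c(N[C@@H]2C[C@H](CO)[C@@H](O)[C@H]2O)n1` carries fluoro in place of hydrogen on an aromatic carbon. Going by the values given here, no measured step covers a change of this kind, and the one measured step concerns a different replacement, so no shift beyond the scatter is expected in this assay. Compound 3 is therefore expected to show no change at the digits printed from compound 2 to compound 3 (within the scatter). Compound 3 is estimated at 14000 nM, within 6000 nM to 30000 nM.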

Compound 3, half-maximal cytotoxic concentration: > 25000 nM
Compound 3 ended at the assay's limit (the forecaster's own chance of this, stated with the estimate: 30%); middle value at least 1.7-fold (0.25 log units) away from the limit.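

In this assay, fluoro in place of hydrogen on the six-membered aromatic ring of carbon only gives an at least 1.7-fold higher number from compound 2 to compound 3 (0.25 log units; that floor lies within the scatter), so this carbon carries fluoro without any lower number appearing. The earlier compounds shown here held no change on this ring, only the swap of the whole group on the core. The size of the new step stays a floor: the limit of > 25000 nM in this assay, at which 2 of the 3 values shown sit.

Going by these compounds, whether an amine, a methoxy group or a carboxylic acid on the same carbon would give a measured number remains open. So does the effect of fluoro at the other carbons of this ring.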